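A few compounds are considered here, and "the series" means these few. Any claim that something is new, unique, unknown or untested is made for them only; others in the source may bear on it.

- Compound 1 `COc1ccc2c(/C=C(\C)C(=O)c3cc(OC)c(OC)c([Se]C)c3)cn(C)c2c1` gives 44 nM here
- Compound 2 `COc1cc(C(=O)/C(C)=C/c2c[nH]c3ccccc23)cc([Se]C)c1OC` gives 59 nM here

Both numbers come from a functional assay on MCF7 cells (Homo sapiens) for antiproliferative activity, read by MTT assay, with a stated time of 48 h (a lower number here means a stronger inhibitor, a higher number a weaker inhibitor), and are the only ones available so far. Compound 2 at 59 nM lies within the usual scatter of compound 1, so the two cannot be told apart. Compound 3 `COc1cc(C(=O)/C(C)=C/c2cn(C)c3ccccc23)cc([Se]C)c1OC` is compound 2 with a single change, methyl in place of hydrogen on an aromatic nitrogen in words, methyl in place of hydrogen on an aromatic nitrogen. Going by the values given here, no measured pair shows this change alone, so its effect remains unknown. Compound 1 also carries methyl on that nitrogen, though it differs from compound 2 elsewhere too, and compound 1 gives 44 nM in this test. On that basis, no step beyond the scatter is expected in this assay and no clear direction. The estimated step of a 1.2-fold lower number from compound 2 to compound 3 (0.07 log units; within the scatter) is therefore small. For compound 3 the estimate is 50 nM as the expected value, with 15 nM to 170 nM as its expected range.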

Compound 3, half-maximal inhibitory concentration: 77 nM
Estimate against measurement, compound 3: 1.5-fold (0.19 log units) below; the measured number falls inside the stated range.
By their numbers in this assay, from the lowest: compounds 1, 2 and 3 (each within the scatter of the next).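

In this assay, going by these compounds alone, the first direct pair for this change gives a 1.3-fold higher number from compound 2 to compound 3 (0.12 log units; within the scatter), so a methyl can take the place of the hydrogen on this aromatic nitrogen with no difference that can be told from the scatter. The second single-place comparison, hydrogen in place of methoxy on an aromatic carbon, gives a 1.8-fold higher number from compound 1 to compound 3 (0.24 log units; within the scatter), which also stays within the scatter. At this level of resolution, neither site has yet shown that its group matters in this test.

Still open, going by these compounds, is whether a longer chain on that nitrogen, such as propyl, or a chain ending in an amine, would stay in the same range. These compounds also offer no reason for the small size of either step.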